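Ethyl for methyl on a shared core: three limits and an estimate

A few compounds are considered here, and "the series" means these few. Any claim that something is new, unique, unknown or untested is made for them only; others in the source may bear on it.

Compound 1 `Cc1ccc2[nH]c(=O)c(CN(Cc3ccc(C(C)(C)C)cc3)[C@H](C)c3ccc(F)cc3)cc2c1` and compound 2 `CCc1ccc2[nH]c(=O)c(CN(Cc3ccc(C(C)(C)C)cc3)[C@H](C)c3ccc(F)cc3)cc2c1` share one core and differ by methyl in place of hydrogen on a saturated chain carbon bound to an aromatic carbon. In a toxicity assay on MDCK cells (Canis lupus familiaris) for cytotoxicity, read by crystal violet staining, with a stated time of 48 h (a lower number here means that less compound is tolerated, a higher number that more compound is tolerated), compound 1 gives only a limit, > 5000 nM. Compound 2 likewise reaches only a limit in this assay, > 5000 nM. The step that the two limits leave unreadable from compound 1 to compound 2 therefore cannot be sized, since both readings sit at the limit of > 5000 nM in this assay, at which 3 of the 3 values shown sit.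

Compound 3 `COc1ccc(C(C)N(Cc2ccc(C(C)(C)C)cc2)Cc2cc3cc(C)ccc3[nH]c2=O)cc1` differs from compound 1 by 1-(4-methoxyphenyl)ethyl in place of 1-(4-fluorophenyl)ethyl on an amine nitrogen. In this assay compound 3 also gives only a limit, > 5000 nM. The step that the two limits leave unreadable from compound 1 to compound 3 is equally unreadable for that reason, both values being at the limit of > 5000 nM in this assay, at which 3 of the 3 values shown sit.

Compound 4 `CCc1ccc2[nH]c(=O)c(CN(Cc3ccc(C(C)(C)C)cc3)C(C)c3ccc(OC)cc3)cc2c1`, not yet measured, differs from compound 3 by methyl in place of hydrogen on a saturated chain carbon bound to an aromatic carbon, the same change as that from compound 1 to compound 2, at the same place. Because the earlier step that the two limits leave unreadable from compound 1 to compound 2 left both ends at the limit of > 5000 nM in this assay, at which 3 of the 3 values shown sit, the step that the limit leaves unreadable from compound 3 to compound 4 is expected to be small. Compound 4 is expected to sit in this assay near 10000 nM, most likely again reported only as a limit, between 4000 nM and 40000 nM.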

Compound 4, half-maximal cytotoxic concentration: > 5000 nM
Compound 4 gave a limit, no number; the forecaster's own chance of this, stated with the estimate: 85%; the middle value lies beyond the limit too.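

Neither new step, between compound 3 and compound 4 or between compound 2 and compound 4, can be read, because all four compounds give only a limit: the limit of > 5000 nM in this assay, at which 4 of the 4 values shown sit.

The compounds shown leave open what concentration of any of them is cytotoxic in this assay, and whether either structural change alters it at all.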